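Lengthening the acid chain on a thromboxane synthase inhibitor

The source may hold more compounds than are shown below. What is called first, only, known or untested is meant among the compounds shown, and "the series" means these compounds.

Compound 1 `Cc1c(Cc2cccnc2)cc2c(c1CCC(=O)O)CCC(NS(=O)(=O)c1ccc(Cl)cc1)C2`: in an assay on blood with Thromboxane-A synthase (Homo sapiens) as the target (on this read-out lower numbers stand for stronger inhibition and higher numbers for weaker inhibition), compound 1 gives 850 nM.
Compound 2 `O=C(O)CCc1c2c(cc(Cc3cccnc3)c1-c1ccccc1)CC(NS(=O)(=O)c1ccc(Cl)cc1)CC2`: in this assay compound 2 gives only a limit, > 10000 nM.

Compound 1 holds the only number shown in this assay; the other value is the limit of > 10000 nM in this assay, at which 1 of the 2 values shown sits. Going by the values given here, the one measured step, an at least 11-fold higher number from compound 1 to compound 2 (1.07 log units; beyond the scatter), is large, but it changes the methyl group and not the acid chain.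

Compound 3 `Cc1c(Cc2cccnc2)cc2c(c1/C=C/CCCC(=O)O)CCC(NS(=O)(=O)c1ccc(Cl)cc1)C2` differs from compound 1 in another way: 5-carboxypent-1-en-1-yl in place of 2-carboxyethyl on an aromatic carbon. Among the compounds with values here, no measured step touches this chain, so the step from compound 1 to compound 2 gives no direct guide to its size. With nothing to point either way, the estimate for compound 3 rests on compound 1 alone, and the expected step of a 1.2-fold lower number from compound 1 to compound 3 (0.08 log units; within the scatter) is taken as small, within or close to the scatter, with the range widened to allow for a larger shift in either direction. Compound 3 is therefore expected to give about 700 nM in this assay, between 150 nM and 3500 nM.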

Compound 3, half-maximal inhibitory concentration: 2900 nM
Compound 3: the middle estimate sits 4.1-fold (0.62 log units) below what was measured; low and high end bracket the measured number.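

Putting 5-carboxypent-1-en-1-yl in place of 2-carboxyethyl, on the aromatic carbon ortho to the methyl group, gives a 3.4-fold higher number from compound 1 to compound 3 (0.53 log units; beyond the scatter) in this assay (a modest step, but beyond the scatter). Going by these compounds alone, this is the first sign that the read-out responds to the acid chain itself, and the direction is towards weaker inhibition: the longer chain with its added double bond brings no gain over the shorter chain of compound 1. The step is still only modest, and compound 3 keeps a measured number, so the position accepts a longer acid chain with some loss rather than a complete one, though nothing shown here accounts for that loss.

The compounds shown leave open whether the loss belongs to the added chain length or to the double bond, as the entering chain brings both at once. Going by these compounds, a saturated 5-carboxypentyl chain or a shorter 3-carboxyprop-1-en-1-yl chain at the same place would separate the two, and it also stays open how a chain ending in an amide rather than a carboxylic acid would read in this assay (the same read-out).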